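A Hydroxypyrrolidine Amide Returns in the Opposite Hand

A few compounds are considered here, and "the series" means these few. Any claim that something is new, unique, unknown or untested is made for them only; others in the source may bear on it.

Compound 2 `COc1ccc(C#Cc2ccc(C(=O)N3CC4CCC(O)C4C3)cc2)cc1` gives 5500 nM in a functional assay on TREX cells for negative allosteric modulation of metabotropic glutamate receptor 3 (Rattus norvegicus), read by calcium flux, with a stated time of 2.5 min (on this read-out higher numbers stand for weaker inhibition and lower numbers for stronger inhibition), the lower of the two numbers recorded, while compound 1 `COc1ccc(C#Cc2ccc(C(=O)N3CC[C@@H](O)C3)cc2)cc1` gives 10200 nM. The step of a 1.9-fold lower number from compound 1 to compound 2 (0.27 log units; within the scatter) was the only one measured. For the measured compounds named here, compound 3 `COc1ccc(C#Cc2ccc(C(=O)N3CC[C@H](O)C3)cc2)cc1` carries a group of 6 heavy atoms (4 carbon, 1 nitrogen, 1 oxygen; one five-membered non-aromatic ring with 1 hetero atom) in place of a group of 9 heavy atoms (7 carbon, 1 nitrogen, 1 oxygen; one five-membered non-aromatic ring of carbon only, one five-membered non-aromatic ring with 1 hetero atom), on a carbonyl carbon; the incoming ring is the mirror image of the one in compound 1. That step is therefore read in reverse, and nothing measured separates the two hands. For compound 3 a step of a 1.6-fold higher number from compound 2 to compound 3 (0.21 log units; within the scatter) is expected, so that compound 3 is estimated at 9000 nM, with a range from 4000 nM to 25000 nM.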

Compound 3, half-maximal inhibitory concentration: 27500 nM
The estimate for compound 3 lay 3.1-fold (0.49 log units) below the measured number; measured number above the stated range.
By their numbers in this assay, from the lowest: compounds 2 and 1 (each within the scatter of the next); then compound 3.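

In this assay the hand of the 3-hydroxypyrrolidin-1-yl group on the carbonyl carbon matters, with a 2.7-fold higher number from compound 1 to compound 3 (0.43 log units; beyond the scatter), and that gap can be put down to the stereocentre alone: the fact that compounds 1 and 3 differ only in the configuration as drawn

Replacing the larger group of compound 2 by the S-drawn ring gives a 5.0-fold higher number from compound 2 to compound 3 (0.70 log units; beyond the scatter), while the R-drawn ring of compound 1 stays within the scatter of compound 2, so the earlier step held for one hand only.

Going by these compounds, it remains open whether the hand would still count with an amine or a methoxy group in place of the hydroxy group, and how the stereocentres of compound 2, which are not drawn, would compare.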